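This account rests on a few compounds, and the source may have more. Where it says the series, first, only, none or still open, it means among the compounds named here.

Working notes on the series. Compound 2 `COc1cc(-c2nn(-c3cccc(NC(=O)c4cccc(C(F)(F)F)c4)c3)cc2-c2ccncc2)ccc1Cl` is one of three measured members. In a functional assay on K562 cells (Homo sapiens) for inhibition, read by sulforhodamine B assay, with a stated time of 48 h (a higher number here means a weaker inhibitor of growth, a lower number a stronger inhibitor of growth), compound 2 gives only a limit, > 50000 nM. Compound 1 `O=C(Nc1cccc(-n2cc(-c3ccncc3)c(-c3ccc(Cl)c(O)c3)n2)c1)Nc1ccc(Cl)c(Cl)c1` in this assay likewise gives only a limit, > 32500 nM. Among the measured compounds shown here, compound 3 `O=C(Nc1cccc(-n2cc(-c3ccncc3)c(-c3ccc(Cl)c(O)c3)n2)c1)Nc1cc(C(F)(F)F)cc(C(F)(F)F)c1` is the single member with a number in this assay, at 3930 nM. Compound 2 therefore stands at the limit of > 50000 nM in this assay, at which 1 of the 3 values shown sits. Compound 1 stands at the limit of > 32500 nM in this assay, at which 1 of the 3 values shown sits. Only compound 3 reaches total growth inhibition inside the measured range.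

Compound 4 `COc1cc(-c2nn(-c3cccc(NC(=O)c4ccccc4)c3)cc2-c2ccncc2)ccc1Cl` is not yet measured. It differs from compound 2 by hydrogen in place of trifluoromethyl on an aromatic carbon. For the measured compounds named here, no measured step between two compounds that differ in one place is available, so the size of this change in this assay cannot be read from the data. With compound 2 already at a limit, the step that the limit leaves unreadable from compound 2 to compound 4 is expected to be none beyond the scatter, or a shift toward weaker growth inhibition. Compound 4 is estimated at 60000 nM, within 25000 nM to 150000 nM, and is expected most likely to be reported again as a limit rather than a number.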

Compound 4, concentration for total growth inhibition: > 100000 nM
Compound 4: only a limit was reported; the forecaster's own chance of this, stated with the estimate: 80%; middle value at least 1.6-fold (0.22 log units) away from the limit.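

In this assay compound 2 gives only a limit, > 50000 nM. Among the compounds shown here, compound 4 likewise gives only a limit, > 100000 nM, so no step from compound 2 to compound 4 can be read. The compounds shown leave open how far hydrogen in place of trifluoromethyl on an aromatic carbon shifts total growth inhibition.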